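Chain-methylation step from compound 1 in the electroshock series

The compounds below may be only part of what the source reports. "The series", "measured", "known", "first", "only" and "open" are said of these compounds alone.

Measured so far:
compound 1 `CC(C(=O)N1CCN(c2ccccc2)CC1)N1C(=O)CCC1=O`: 100%
compound 2 `CC(C(=O)N1CCN(c2cccc(C(F)(F)F)c2)CC1)N1C(=O)CCC1=O`: 75%
compound 3 `Cc1cccc(N2CCN(C(=O)C(C)N3C(=O)CCC3=O)CC2)c1`: 100%

In a functional assay on the whole organism (strain Swiss) with Mus musculus as the target, in the maximal electroshock model, with a stated time of 0.25 h, at a dose of 300 mg/kg by the intraperitoneal route (a higher number here means a stronger effect of the compound at the dose given, a lower number a weaker effect), compound 1 stands level with compound 3, the two together the highest of the three numbers, with compound 2 the furthest away: a number 25 percentage points lower from compound 1 to compound 2 (beyond the scatter) and no change at the digits printed from compound 1 to compound 3 (within the scatter). Both measured steps alter the aromatic ring only.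

Compound 4 `CCC(C(=O)N1CCN(c2ccccc2)CC1)N1C(=O)CCC1=O` differs from compound 1 at the chain instead: methyl in place of hydrogen on a saturated chain carbon, two bonds along the chain from an amide-type nitrogen in a ring and a carbonyl carbon. Cut one bond further out the change reads methyl to ethyl. Among the measured compounds shown here, no measured step touches this chain carbon, so the ring steps give no direct guide; the ring steps themselves ranged from none to modest in this assay. A change of no more than modest size is expected: no change at the digits printed from compound 1 to compound 4 (within the scatter). Compound 4 is expected to give 100% in this assay, within 75% to 100%.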

Compound 4, a percentage reported as activity, at one dose (the size of the read-out at that dose, not a potency): 75%
The estimate for compound 4 lay 25 percentage points above the measured number; measured number inside the range.
By their numbers in this assay, from the lowest: compounds 2 and 4 (each within the scatter of the next); then compounds 1 and 3 (each within the scatter of the next).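

The saturated chain carbon is a position where the read-out of this assay responds: methyl in place of hydrogen there gives a number 25 percentage points lower from compound 1 to compound 4 (beyond the scatter) in this series. The same replacement on an aromatic carbon gives no change at the digits printed from compound 1 to compound 3 (within the scatter), so the outcome of this small change depends on where it is made. No measurement shown offers an explanation for the chain step.

On these data alone, whether a propyl chain or a hydroxymethyl group at this carbon would give a number different from that of compound 4 remains open. Also open, as far as these compounds go, is how the chain change would read on the trifluoromethyl-bearing core of compound 2.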